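This account rests on a few compounds, and the source may have more. Where it says the series, first, only, none or still open, it means among the compounds named here.

Measured compounds in an assay on cell membranes for displacement of a labelled ligand from Neuronal acetylcholine receptor; alpha4/beta2 (Rattus norvegicus), read by scintillation counting; a higher number here means a weaker inhibitor, a lower number a stronger inhibitor:
compound 1 `COc1ccc(O)cc1OC[C@@H]1CCCN1`, 1080 nM
compound 2 `Oc1cccc(OC[C@@H]2CCCN2)c1`, 407 nM
compound 3 `COc1ncccc1OC[C@@H]1CCCN1C`, 7280 nM

Compound 1 holds the second highest number of the three in this assay: compound 2 sits a 2.7-fold lower number from compound 1 to compound 2 (0.42 log units; beyond the scatter), and compound 3 stands well above both. Compound 4 `COc1ccccc1OC[C@@H]1CCCN1` differs from compound 1 by hydrogen in place of hydroxy on an aromatic carbon. Within the data shown here, no measured pair repeats that change; the one recorded step, a 2.7-fold lower number from compound 1 to compound 2 (0.42 log units; beyond the scatter), removes the methoxy while keeping the hydroxy, and compound 3, which lacks a hydroxy altogether, gives the highest number of the set. Loss of the hydroxy is therefore expected to move the number upward, by a modest step beyond the scatter, a 2.3-fold higher number from compound 1 to compound 4 (0.36 log units; beyond the scatter). Compound 4 is estimated at 2500 nM, within a range of 900 nM to 7000 nM.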

Compound 4, inhibition constant: 53500 nM
Beside the measured number, compound 4's estimate is 21-fold (1.33 log units) below it, outside the stated range (above it).
By their numbers in this assay, from the lowest: compound 2; then compound 1; then compound 3; then compound 4.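

In this assay, hydrogen in place of hydroxy on an aromatic carbon gives a 50-fold higher number from compound 1 to compound 4 (1.69 log units; beyond the scatter), a large step, whereas the earlier step at the methoxy, a 2.7-fold lower number from compound 1 to compound 2 (0.42 log units; beyond the scatter), was modest. Among these compounds, in this pair, the number depends far more on the hydroxy, para to a methoxy group, than the earlier compounds could show. Nothing on hand accounts for the size of this step.

The compounds shown leave open whether an amine or a fluorine at this place would keep the number near that of compound 1. From the compounds shown here alone, whether a step of this size recurs without the methoxy group also stays open.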